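Aryl ketone variation on the acrylonitrile side chain

The compounds below may be only part of what the source reports. "The series", "measured", "known", "first", "only" and "open" are said of these compounds alone.

Measured so far:
- compound 2 `N#C/C(=C\c1c(-c2ccccc2)[nH]c2ccccc12)C(=O)c1cccs1` — a functional assay on MT4 cells (Homo sapiens) for antiproliferative activity, read by MTT assay, with a stated time of 96 h (on this read-out higher numbers stand for an effect only at larger amounts of compound and lower numbers for an effect already at smaller amounts), 400 nM
- compound 3 `O=C(/C(=C\c1c(-c2ccccc2)[nH]c2ccccc12)C(=O)C(F)(F)F)c1ccco1` — in this assay compound 3 gives 800 nM
- compound 1 `N#C/C(=C\c1c(-c2ccccc2)[nH]c2ccccc12)C(N)=O` — in this assay compound 1 gives 6000 nM

Compound 2 holds the lowest number of the three. Compound 3 sits within the scatter of it, so no order between compound 2 and compound 3 can be read. Compound 1 lies beyond the scatter: a 15-fold lower number from compound 1 to compound 2 (1.18 log units; beyond the scatter).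

Compound 4 `N#C/C(=C\c1c(-c2ccccc2)[nH]c2ccccc12)C(=O)c1ccc(Cl)cc1` has not yet been measured in this assay. It differs from compound 2 as follows: 4-chlorophenyl in place of thiophen-2-yl on a carbonyl carbon.

Among the compounds with values here, the only step at the same place, the carbonyl carbon, is a 15-fold lower number from compound 1 to compound 2 (1.18 log units; beyond the scatter), which swaps amino for an aromatic ring. Within the data shown here, no measured pair exchanges one aromatic ring for another at this carbonyl, so that step bears only loosely on the present change. Since compound 4 keeps an aromatic ring on the carbonyl carbon, as compound 2 does, the expected step is a 1.3-fold higher number from compound 2 to compound 4 (0.10 log units; within the scatter), a change not clearly beyond the scatter. The estimate for compound 4 in this assay is 500 nM, within the range 150 nM to 1600 nM.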

Compound 4, half-maximal effective concentration: 400 nM
The estimate for compound 4 lay 1.3-fold (0.10 log units) above the measured number; low and high end bracket the measured number.
By their numbers in this assay, from the lowest: compounds 2, 4 and 3 (each within the scatter of the next); then compound 1.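

In this assay, within the data shown here, the first exchange of one aromatic ring for another on this carbonyl carbon gives no change at the digits printed from compound 2 to compound 4 (within the scatter), so thiophen-2-yl and 4-chlorophenyl cannot be told apart here. The earlier drop from the amide recurs with a second ring, a 15-fold lower number from compound 1 to compound 4 (1.18 log units; beyond the scatter), and therefore does not depend on thiophen-2-yl alone. No evidence is at hand that accounts for either step.

Open, going by these compounds, is whether a ring on the carbonyl carbon is needed at all, since the standing of an n-butyl chain or a piperidin-1-yl group there remains unknown. Also open, on these data alone, is what the chlorine of compound 4 contributes, a question that an unsubstituted phenyl or a methoxy group in place of the chlorine would address.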